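Ethyl to Isopropyl on the Shared Core

A few compounds are considered here, and "the series" means these few. Any claim that something is new, unique, unknown or untested is made for them only; others in the source may bear on it.

Compound 1 `Cc1nn(C)c2c1C(c1ccccc1Cl)=NCC(=O)N2` and compound 2 `CCc1nn(C)c2c1C(c1ccccc1Cl)=NCC(=O)N2` share one core and were both tested in a functional assay on the whole organism with Rattus norvegicus as the target; a higher number here means that more compound is needed for the effect, a lower number that less compound is needed. Compound 1 gives 16 mg/kg, and compound 2 gives 32 mg/kg. Compound 2 holds the higher of the two numbers, yet the gap to its nearest neighbour, compound 1, is only a 2.0-fold higher number from compound 1 to compound 2 (0.30 log units; within the scatter), which lies within the scatter. Compound 3 `CC(C)c1nn(C)c2c1C(c1ccccc1Cl)=NCC(=O)N2` takes the same series one step on: methyl in place of hydrogen on a saturated chain carbon bound to an aromatic carbon and a saturated chain carbon, a difference that, cut one bond further out, reads ethyl to isopropyl. Among the measured compounds shown here, the only measured step that bears on it is the earlier one, a 2.0-fold higher number from compound 1 to compound 2 (0.30 log units; within the scatter), and because that step stayed within the scatter, no step beyond the scatter is expected in this assay, though a drift toward a higher number would follow the same direction. The estimate for compound 3 is therefore 40 mg/kg, with a range of 16 mg/kg to 100 mg/kg. That estimate means an expected step of a 1.3-fold higher number from compound 2 to compound 3 (0.10 log units; within the scatter).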

Compound 3, minimum effective dose: 125 mg/kg
Compound 3: the middle estimate sits 3.1-fold (0.49 log units) below what was measured, outside the stated range (above it).
By their numbers in this assay, from the lowest: compounds 1 and 2 (each within the scatter of the next); then compound 3.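

In this assay, among the compounds shown here, the series moves beyond the scatter for the first time at this position: methyl in place of hydrogen on a saturated chain carbon bound to an aromatic carbon and a saturated chain carbon gives a 3.9-fold higher number from compound 2 to compound 3 (0.59 log units; beyond the scatter) and so does more than the earlier step, which stayed within the scatter. Read across the whole series, isopropyl in place of methyl on an aromatic carbon gives a 7.8-fold higher number from compound 1 to compound 3 (0.89 log units; beyond the scatter) and shows that the number in this assay does depend on the group held at this place. No available evidence explains why this step leaves the scatter when the earlier one did not.

The compounds shown leave open whether a longer chain such as propyl, or a ring such as cyclopropyl, on the same aromatic carbon would give a number like that of compound 3. They also leave open whether a tert-butyl group there would raise the number further.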